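Aryl swap on the saturated ring carbon of the shared core

The source may hold more compounds than are shown below. What is called first, only, known or untested is meant among the compounds shown, and "the series" means these compounds.

Three compounds of this series carry the same core and differ only in the aryl group on a saturated ring carbon. Compound 1, `COc1ccc(C2OC(c3cc(OC)c(OC)c(OC)c3)=NN2C(C)=O)c(OC)c1`, is the reference; in a functional assay on PC-3 cells (Homo sapiens) for antiproliferative activity, read by MTT assay, tested at 1 uM (on this read-out lower numbers stand for a weaker effect and higher numbers for a stronger effect at the one concentration tested), compound 1 gives 69.5%. Compound 2, `COc1cc(C2=NN(C(C)=O)C(c3ccccc3F)O2)cc(OC)c1OC`, gives 13.5%, and compound 3, `COc1cc(C2=NN(C(C)=O)C(c3ccc(F)c(F)c3)O2)cc(OC)c1OC`, gives 35.5%. Compound 3 therefore stands second highest of the three numbers, with compound 2 the nearer neighbour and compound 1 the further one.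

The measured steps show how strongly this aryl group governs the read-out: a number 34 percentage points lower from compound 1 to compound 3 (beyond the scatter), a number 56 percentage points lower from compound 1 to compound 2 (beyond the scatter), and a number 22 percentage points higher from compound 2 to compound 3 (beyond the scatter).

Compound 4, `COc1cc(C2=NN(C(C)=O)C(c3cccc(C(F)(F)F)c3)O2)cc(OC)c1OC`, is the next member. The change from compound 3 is 3-(trifluoromethyl)phenyl in place of 3,4-difluorophenyl on a saturated ring carbon. Going by the values given here, no measured step involves a 3-(trifluoromethyl)phenyl group, so the direction cannot be read off directly; the two steps that bear on it, the change from compound 2 to compound 3 and the change from compound 1 to compound 3, show that single-ring substitution changes at this position move the number by modest to large amounts in either direction. For compound 4 the expected step is a number 3.5 percentage points lower from compound 3 to compound 4 (within the scatter), a number close to compound 3. Compound 4 is thus estimated at 32%, within 10% to 55%.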

Compound 4, a percentage reported as inhibition, at one concentration (the size of the read-out at that concentration, not a potency): 30.1%
Beside the measured number, compound 4's estimate is 1.9 percentage points above it; measured number inside the range.
By their numbers in this assay, from the lowest: compound 2; then compounds 4 and 3 (each within the scatter of the next); then compound 1.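

In this assay, going by these compounds alone, the swap of 3,4-difluorophenyl for 3-(trifluoromethyl)phenyl on the saturated ring carbon gives a number 5.4 percentage points lower from compound 3 to compound 4 (within the scatter), the first aryl change that stays inside the scatter, even though the entering group is larger by the count of heavy atoms. Compound 4 also repeats the placing of compound 3 relative to the two other aryl groups, with a number 16.6 percentage points higher from compound 2 to compound 4 (beyond the scatter) and a number 39.4 percentage points lower from compound 1 to compound 4 (beyond the scatter), so among these four compounds the 2,4-dimethoxyphenyl group of compound 1 stands clearly highest, the 2-fluorophenyl group of compound 2 clearly lowest, and the two other fluorine-bearing groups together in the middle. No measurement is at hand that explains these differences.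

On these data alone, it remains open whether a phenyl ring bearing a single methoxy group, an amine or a carboxylic acid at this position would fall nearer to compound 1 or to compound 2. Each number also comes from one concentration and shows only the size of the effect at that concentration, so whether the effects of these compounds, including compound 3 and compound 4, would compare in the same way at other concentrations remains unsettled.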